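Whole-animal series: aryl acrylate esters of a trimethoxycinnamyl alcohol

A few compounds are considered here, and "the series" means these few. Any claim that something is new, unique, unknown or untested is made for them only; others in the source may bear on it.

Measured so far:
compound 1 `COc1cc(OC)c(OC)cc1/C=C/COC(=O)/C=C/c1c(OC)ccc(OC)c1OC` — 100%
compound 2 `COc1cc(OC)c(OC)cc1/C=C/COC(=O)/C=C/c1ccccc1C(F)(F)F` — 100%
compound 3 `COc1cc(OC)c(OC)cc1/C=C/COC(=O)/C=C/c1cc(OC)c(OC)c(OC)c1` — 100%

In a functional assay on the whole organism (strain Kunming) with Mus musculus as the target, with a stated time of 0.5 h, at a dose of 100 mg/kg by the intraperitoneal route (on this read-out lower numbers stand for a stronger effect and higher numbers for a weaker effect at the one dose given), compound 1 gives 100%, compound 2 gives 100% and compound 3 gives 100%. Compound 2 stands level with compound 1 and with compound 3 at the digits shown; no pair differs beyond the scatter, so no step among the measured compounds is resolved.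

Compound 4 `COc1cccc(/C=C/C(=O)OC/C=C/c2cc(OC)c(OC)cc2OC)c1` is not yet measured. It differs from compound 2 as follows: 3-methoxyphenyl in place of 2-(trifluoromethyl)phenyl on a double-bonded chain carbon bound to a double-bonded chain carbon. Among the measured compounds shown here, no measured step exists to rest on, and all three measured compounds sit at the same read-out. The step of a number 2 percentage points lower from compound 2 to compound 4 (within the scatter) is therefore expected to be none beyond the scatter. Compound 4 is expected to give 98%, with a range from 80% to 100%.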

Compound 4, a percentage reported as activity, at one dose (the size of the read-out at that dose, not a potency): 100%
For compound 4 the middle estimate is 2 percentage points below the measured one; measured number inside the range.
By their numbers in this assay, from the lowest: compounds 1, 2, 3 and 4 (each within the scatter of the next).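

In this assay, 3-methoxyphenyl in place of 2-(trifluoromethyl)phenyl on a double-bonded chain carbon bound to a double-bonded chain carbon gives no change at the digits printed from compound 2 to compound 4 (within the scatter). Among the compounds shown here, this is the only single-place step, and at this place the read-out does not separate the two aryl groups, although three fluorine atoms leave and one oxygen enters. No supporting measurement bears on this flat result. On these data alone, whether an amine or a carboxylic acid at this place would shift the read-out stays open. Also open, as far as these compounds go, is whether any change to the shared core would move it at the one dose given.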